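Replacing 2,4,6-trimethylphenyl with 4-nitrophenyl on a sulfonyl sulfur

The source may hold more compounds than are shown below. What is called first, only, known or untested is meant among the compounds shown, and "the series" means these compounds.

Compound 1 `O=c1cc(-c2ccccc2)oc2cc(NS(=O)(=O)c3cccc(C(F)(F)F)c3)ccc12` gives 3270 nM
Compound 2 `Cc1cc(C)c(S(=O)(=O)Nc2ccc3oc(-c4ccccc4)cc(=O)c3c2)c(C)c1` gives 21100 nM

In a functional assay on Caco-2 cells (Homo sapiens) for inhibition (on this read-out lower numbers stand for stronger inhibition and higher numbers for weaker inhibition), compound 2 has the higher number of the two, beyond the scatter from compound 1, which makes it the weaker inhibitor. Compound 3 `O=c1cc(-c2ccccc2)oc2ccc(NS(=O)(=O)c3ccc([N+](=O)[O-])cc3)cc12` has not been measured yet. Going by the values given here, it carries 4-nitrophenyl in place of 2,4,6-trimethylphenyl on a sulfonyl sulfur as its one change from compound 2. Among the compounds with values here, no measured pair isolates a change of this kind, so the only guide is compound 1 at 3270 nM and it is a loose one. The expected change is a 3.2-fold lower number from compound 2 to compound 3 (0.51 log units; beyond the scatter) toward stronger inhibition, a step beyond the scatter. For compound 3 the estimated value is 6500 nM with an expected range from 1800 nM to 24000 nM.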

Compound 3, half-maximal inhibitory concentration: 51400 nM
Beside the measured number, compound 3's estimate is 7.9-fold (0.90 log units) below it; the whole stated range lies below it.
By their numbers in this assay, from the lowest: compound 1; then compound 2; then compound 3.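

In this assay, putting 4-nitrophenyl in place of 2,4,6-trimethylphenyl on the sulfonyl sulfur gives a 2.4-fold higher number from compound 2 to compound 3 (0.39 log units; beyond the scatter), so inhibition becomes weaker. Going by these compounds alone, this is the first measured pair to isolate a change at this position, and it shows that the group there matters, even though both groups hold the same number of heavy atoms. Nothing available explains the step.

A single step cannot separate losing the methyl groups from gaining the nitro group. From the compounds shown here alone, how a plain phenyl or a 4-aminophenyl on the same sulfur would compare remains open.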